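A few compounds are considered here, and "the series" means these few. Any claim that something is new, unique, unknown or untested is made for them only; others in the source may bear on it.

Measured compounds:
- Compound 1 `CN(C(=O)NC(=O)c1c(F)cccc1F)c1nc(C(F)(F)F)c(C(=O)N/N=C/c2cccc(C(F)(F)F)c2)s1`; in a functional assay on HeLa cells (Homo sapiens) for inhibition, read by MTT assay, with a stated time of 72 h (on this read-out higher numbers stand for weaker inhibition and lower numbers for stronger inhibition), compound 1 gives 21.6 ug/mL.
- Compound 2 `Cc1nc(N(C)C(=O)NC(=O)c2c(F)cccc2F)sc1C(=O)N/N=C/c1cccc(C(F)(F)F)c1`; in this assay compound 2 gives 26.8 ug/mL.
- Compound 3 `Cc1nc(N(C)C(=O)NC(=O)c2c(F)cccc2F)sc1C(=O)N/N=C/c1cc(C(F)(F)F)cc(C(F)(F)F)c1`; in this assay compound 3 gives 12.2 ug/mL.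

Compound 2 carries the highest of the three numbers, although compound 1 stands within the scatter of it: the step of a 1.2-fold higher number from compound 1 to compound 2 (0.09 log units; within the scatter) is too small to count. Going by the values given here, the only step beyond the scatter is a 2.2-fold lower number from compound 2 to compound 3 (0.34 log units; beyond the scatter), a modest one.

Compound 4 `Cc1nc(N(C)C(=O)NC(=O)c2c(F)cccc2F)sc1C(=O)N/N=C/c1ccccc1C(F)(F)F` differs from compound 2 by 2-(trifluoromethyl)phenyl in place of 3-(trifluoromethyl)phenyl on a carbon with a double bond to nitrogen. Neither measured step bears on this kind of change: the step from compound 1 to compound 2 exchanges one group for another on the shared core, and the step from compound 2 to compound 3 adds a trifluoromethyl to the ring that hangs from the carbon double-bonded to nitrogen. Among the compounds with values here, no measured pair moves a group from one ring position to another while the atoms stay the same. With nothing to point either way, the expectation for compound 4 is a step of a 1.1-fold lower number from compound 2 to compound 4 (0.03 log units; within the scatter), that is, none beyond the scatter. Compound 4 is therefore estimated at 25 ug/mL in this assay, with a range from 10 ug/mL to 60 ug/mL.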

Compound 4, half-maximal inhibitory concentration: 6.51 ug/mL
Compound 4: the middle estimate sits 3.8-fold (0.58 log units) above what was measured; measured number outside the range, below it.
By their numbers in this assay, from the lowest: compounds 4, 3, 1 and 2 (each within the scatter of the next, the first and the last beyond it).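

In this assay, the ring on the carbon with a double bond to nitrogen responds to where its trifluoromethyl stands, not only to whether one is added: the change to 2-(trifluoromethyl)phenyl from 3-(trifluoromethyl)phenyl gives a 4.1-fold lower number from compound 2 to compound 4 (0.61 log units; beyond the scatter) with the same atoms. Going by these compounds alone, until now, the only change beyond the scatter on this ring was an added trifluoromethyl (a 2.2-fold lower number from compound 2 to compound 3 (0.34 log units; beyond the scatter)). No measurement shown accounts for the effect of this shift.

Still open, from the compounds shown here alone, is whether the number seen with 2-(trifluoromethyl)phenyl depends on the trifluoromethyl itself, or whether a methoxy group, a chlorine or a nitrile in the same ring place would give a similar number. Also open, going by these compounds, is whether the shift gives a similar step when the shared core carries the trifluoromethyl of compound 1 in place of the methyl.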